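This account rests on a few compounds, and the source may have more. Where it says the series, first, only, none or still open, it means among the compounds named here.

Of the compounds shown here, three have so far been tested in a functional assay on HepG2 cells (Homo sapiens) for inhibition, read by MTT assay, with a stated time of 48 h; a lower number here means a stronger inhibitor, a higher number a weaker inhibitor. Compound 1 `Fc1ccc(/C=N/Nc2nc(-c3ccc(C(F)(F)F)cc3)cs2)cc1F` gives 14500 nM in this assay. Compound 2 `Fc1ccc(/C=N/Nc2nc(-c3ccccc3)cs2)cc1F` differs from compound 1 in one place: hydrogen in place of trifluoromethyl on an aromatic carbon. For compound 2 this assay reports only a limit, not a number, namely > 100000 nM. That reading is the limit of > 100000 nM in this assay, at which 1 of the 3 values shown sits. Put side by side, the change gives an at least 6.8-fold higher number from compound 1 to compound 2 (0.83 log units; beyond the scatter), so the compound without the trifluoromethyl group is the weaker inhibitor of the two.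

Compound 3 `COc1cc(/C=N/Nc2nc(-c3ccc(C(F)(F)F)cc3)cs2)cc(Br)c1OC` gives 31200 nM in this assay, a weaker result than compound 1. The difference between the core of compound 3 and the core of compound 1 is not broken down here.

Compound 4 `COc1cc(/C=N/Nc2nc(-c3ccccc3)cs2)cc(Br)c1OC` has not yet been measured. It differs from compound 3 by hydrogen in place of trifluoromethyl on an aromatic carbon, the same change that turns compound 1 into compound 2. If the change behaves the same way on this second core, the expected step is a 6.4-fold higher number from compound 3 to compound 4 (0.81 log units; beyond the scatter), an estimate that rests on the measured step of an at least 6.8-fold higher number from compound 1 to compound 2 (0.83 log units; beyond the scatter). Compound 4 is therefore expected to give about 200000 nM in this assay, with a likely range from 60000 nM to 800000 nM. Since compound 3 already sits well up the scale, it is quite possible that this assay will report only a limit for compound 4 rather than a number.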

Compound 4, half-maximal inhibitory concentration: 68300 nM
For compound 4 the middle estimate is 2.9-fold (0.47 log units) above the measured one; measured number inside the range.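

Replacing trifluoromethyl with hydrogen weakens inhibition on the second core too: in this assay the measured change is a 2.2-fold higher number from compound 3 to compound 4 (0.34 log units; beyond the scatter). The direction of the change therefore carries over from one core to the other, but its size does not: the same change on two cores in this assay, an at least 6.8-fold higher number (0.83 log units; beyond the scatter) from compound 1 to compound 2 and a 2.2-fold higher number (0.34 log units; beyond the scatter) from compound 3 to compound 4, at least 3.1-fold (0.49 log units) apart, beyond the scatter of two such steps

On these data alone, compound 2 stands at > 100000 nM, which is a limit of the assay and not a number, so the true size of the step on the first core remains unknown, and two cores cannot establish a general rule or show what in the cores makes the two steps differ.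

The compounds shown leave open how a nitrile, an amine or a carboxylic acid would compare with trifluoromethyl and hydrogen at that same place on either core. They also leave open whether a third core would keep the same direction, and whether its step would lie closer to the larger or the smaller of the two seen here.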